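Cyclohexyl for methyl on the pyranone core

The source may hold more compounds than are shown below. What is called first, only, known or untested is meant among the compounds shown, and "the series" means these compounds.

The series rests on a shared core in which an anilino group and a second substituent sit on the same ring. Compound 1, `COc1cccc(Nc2cc(-c3ccccc3)oc(=O)c2)c1`, carries a phenyl group, and in a functional assay on DU-145 cells (Homo sapiens) for cytotoxicity, read by MTT assay, with a stated time of 72 h (a lower number here means that less compound is needed, a higher number that more compound is needed for the effect), compound 1 gives 0.66 uM. Compound 2, `COc1ccc(Nc2cc(C)oc(=O)c2)cc1`, carries a methyl group in the same place, and in this assay compound 2 reaches only a limit, > 30 uM. That limit, (the limit of > 30 uM in this assay, at which 1 of the 2 values shown sits), is all that is known of compound 2 here, so it stands at the weak end of the two values shown. Compound 3, `COc1ccc(Nc2cc(C3CCCCC3)oc(=O)c2)cc1`, differs from compound 2 by cyclohexyl in place of methyl on an aromatic carbon. Among the measured compounds shown here, no measured step between two compounds covers this change, so the expected step from compound 2 to compound 3 , an at least 3.7-fold lower number from compound 2 to compound 3 (0.57 log units; beyond the scatter), is a guess toward a lower concentration rather than a figure read from a pair. Compound 3 is estimated at 8 uM, within a range from 1.5 uM to 40 uM.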

Compound 3, concentration for half-maximal effect: 8.61 uM
Compound 3: middle estimate off by 1.1-fold (0.03 log units), on the low side; low and high end bracket the measured number.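

Cyclohexyl in place of methyl, on the aromatic carbon next to the ring oxygen, gives the first measured step at this position in this assay: an at least 3.4-fold lower number from compound 2 to compound 3 (0.54 log units; beyond the scatter). It shows that this place accepts a six-membered non-aromatic ring of carbon only, and that the number then lies beyond the scatter from the methyl compound. The true size of the step stays unknown because compound 2 stands at a limit and not at a number: the limit of > 30 uM in this assay, at which 1 of the 3 values shown sits.

Compound 1 differs from compound 3 in more than one place, so the compounds shown do not separate the effect of phenyl from that of cyclohexyl at this position. They also leave open how an amine, a carboxylic acid or a longer alkyl chain would behave there.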